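Ether Swap: From Pyridinyl to Difluorocyclohexyl

A few compounds are considered here, and "the series" means these few. Any claim that something is new, unique, unknown or untested is made for them only; others in the source may bear on it.

Measured in an ADME assay on microsomes from liver (Homo sapiens) for metabolic stability, read by HPLC, using NADPH, with stated times of 5 min and 60 min, tested at 10 uM; a lower number here means slower removal, a higher number faster removal of the compound:
compound 1 `Cn1cc(-c2cc(NS(C)(=O)=O)ccc2Oc2ccccc2C(F)(F)F)c2cc[nH]c2c1=O` gives 533 mL/min/kg
compound 2 `Cn1cc(-c2cc(NS(C)(=O)=O)ccc2Oc2ccc(F)cc2Cl)c2cc[nH]c2c1=O` gives 233 mL/min/kg
compound 3 `Cn1cc(-c2cc(NS(C)(=O)=O)ccc2Oc2cccnc2)c2cc[nH]c2c1=O` gives 86.7 mL/min/kg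

Compound 3 stands lowest of the three: a 2.7-fold lower number from compound 2 to compound 3 (0.43 log units; beyond the scatter) and a 6.1-fold lower number from compound 1 to compound 3 (0.79 log units; beyond the scatter). Compound 4 `Cn1cc(-c2cc(NS(C)(=O)=O)ccc2OC2CCC(F)(F)CC2)c2cc[nH]c2c1=O` differs from compound 3 in one place: 4,4-difluorocyclohexyl in place of pyridin-3-yl on an oxygen on an aromatic ring. Every measured step exchanges one aromatic ring for another, a 2.3-fold lower number from compound 1 to compound 2 (0.36 log units; beyond the scatter) among them, and none trades an aromatic ring for a six-membered non-aromatic ring of carbon only, so they bear on this change only loosely. Since compound 3 sits at the low end of the numbers seen, a modest rise in this assay is expected, that is a 1.7-fold higher number from compound 3 to compound 4 (0.24 log units; within the scatter). Compound 4 is therefore estimated at about 150 mL/min/kg, within 60 mL/min/kg to 400 mL/min/kg.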

Compound 4, clearance: < 38.4 mL/min/kg
Compound 4: only a limit was reported; the forecaster's own chance of this, stated with the estimate: 0%; middle value at least 3.9-fold (0.59 log units) away from the limit.
By their numbers in this assay, from the lowest: compound 3; then compound 2; then compound 1. At a limit, below all of these: compound 4.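

Until this point every swap on this oxygen put one aromatic ring in place of another; here a six-membered non-aromatic ring of carbon only enters, and in this assay the change gives an at least 2.2-fold lower number from compound 3 to compound 4 (0.35 log units; beyond the scatter). The gap to the two substituted phenyl ethers is wider still, with an at least 6.0-fold lower number from compound 2 to compound 4 (0.78 log units; beyond the scatter) and an at least 13-fold lower number from compound 1 to compound 4 (1.14 log units; beyond the scatter). Compound 4 gives only a limit of the assay, not a number: the limit of < 38.4 mL/min/kg in this assay, at which 1 of the 4 values shown sits.

Open, from the compounds shown here alone, is how a plain cyclohexyl or a piperidine ring, which carries an amine, would fare on this oxygen. That leaves unsettled whether the two fluorines matter or the non-aromatic ring alone is enough.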